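Loss of (1-bromoethenyl)carbonyl from compound 2

A few compounds are considered here, and "the series" means these few. Any claim that something is new, unique, unknown or untested is made for them only; others in the source may bear on it.

In a functional assay on FM3A cells (Mus musculus) for antiproliferative activity, with a stated time of 48 h (a lower number here means a stronger inhibitor, a higher number a weaker inhibitor), compound 1 (`C=C(Br)C(=O)Nc1ccc(C(=O)/C=C/c2cccc(OC)c2)cc1`) gives 1800 nM, compound 2 (`C=C(Br)C(=O)Nc1ccc(C(=O)/C=C/c2cc(OC)cc(OC)c2)cc1`) gives 2000 nM and compound 3 (`C=C(Br)C(=O)Nc1ccc(C(=O)/C=C/c2cc(OC)c(OC)c(OC)c2)cc1`) gives 1800 nM. Compound 2 therefore sits level with both neighbours, within the scatter. Within the data shown here, the only measured changes are methoxy in place of hydrogen on an aromatic carbon: a 1.1-fold higher number from compound 1 to compound 2 (0.05 log units; within the scatter) and a 1.1-fold lower number from compound 2 to compound 3 (0.05 log units; within the scatter), both within the scatter.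

Compound 4 (`COc1cc(/C=C/C(=O)c2ccc(N)cc2)cc(OC)c1`) departs from compound 2 elsewhere, with hydrogen in place of (1-bromoethenyl)carbonyl on a nitrogen on an aromatic ring. Among the measured compounds shown here, the methoxy steps do not bear directly on this change, and no measured compound lacks the group. Their flatness shows only that the methoxy count leaves the numbers in this assay unmoved. For the measured compounds named here, with the group common to all three measured compounds, its loss is the one untested change, and a clear move toward a weaker inhibitor is expected. The expected shift is a 7.5-fold higher number from compound 2 to compound 4 (0.88 log units; beyond the scatter), beyond the scatter. For compound 4 the estimated value is 15000 nM, with an expected range of 4000 nM to 50000 nM.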

Compound 4, half-maximal inhibitory concentration: 12000 nM
For compound 4 the middle estimate is 1.3-fold (0.10 log units) above the measured one; measured number inside the range.
By their numbers in this assay, from the lowest: compounds 1, 3 and 2 (each within the scatter of the next); then compound 4.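

In this assay, hydrogen in place of (1-bromoethenyl)carbonyl on the nitrogen gives a 6.0-fold higher number from compound 2 to compound 4 (0.78 log units; beyond the scatter), the only step shown that lies beyond the scatter. This places the measurable change in the series at this nitrogen rather than in the methoxy count, while compound 4 still gives a finite 12000 nM with the free amino group, so the number rises without the group but remains measurable. No measured evidence accompanies this step to account for the shift.

The compounds shown do not separate the bromine from the rest of the group, and an acetyl or a (1-chloroethenyl)carbonyl group on the same nitrogen would address that. Also open is whether the methoxy count stays without effect among the free amines, as compound 4 is the only one shown.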